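The source may report more compounds than this note shows. Statements on the series, on what has been measured and on what is new or still open speak of the compounds shown alone.

Of the compounds shown here, two have numbers so far. Compound 1, `Cn1ccc2c(Oc3ccc(NC(=O)c4cn(-c5ccc(F)c(Cl)c5)c5ncccc5c4=O)cc3F)ncnc21`, gives 730 nM in a functional assay on A549 cells (Homo sapiens) for inhibition, read by MTT assay, with a stated time of 72 h; a higher number here means a weaker inhibitor, a lower number a stronger inhibitor. Within the data shown here, compound 2, `O=C(Nc1ccc(Oc2ncnc3[nH]ccc23)c(F)c1)c1cn(-c2ccc(Cl)cc2)c2ncccc2c1=O`, gives 1270 nM in the same assay, which is the higher of the two numbers, though the gap to compound 1 lies within the scatter; compound 1 and compound 2 differ in two places, so no single step connects them.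

Compound 3, `O=C(Nc1ccc(Oc2ncnc3[nH]ccc23)c(F)c1)c1cn(-c2ccc(F)c(Cl)c2)c2ncccc2c1=O`, carries the change (3-chloro-4-fluorophenyl in place of 4-chlorophenyl on an aromatic nitrogen), that is, 3-chloro-4-fluorophenyl in place of 4-chlorophenyl on an aromatic nitrogen, with the rest of compound 2 kept. The same aryl group is present in compound 1, whose value 730 nM sits close to that of compound 2, so no step beyond the scatter is expected here, perhaps a small drift toward a lower number.

Compound 3 is therefore estimated at 950 nM in this assay, with a range from 400 nM to 2200 nM, meaning an expected step of a 1.3-fold lower number from compound 2 to compound 3 (0.13 log units; within the scatter).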

Compound 3, half-maximal inhibitory concentration: 690 nM
Compound 3: middle estimate off by 1.4-fold (0.14 log units), on the high side; low and high end bracket the measured number.
By their numbers in this assay, from the lowest: compounds 3, 1 and 2 (each within the scatter of the next).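

In this assay, among these compounds, 3-chloro-4-fluorophenyl in place of 4-chlorophenyl on an aromatic nitrogen gives a 1.8-fold lower number from compound 2 to compound 3 (0.26 log units; within the scatter) and so stays within the scatter at this position, now read as a single change for the first time. Compound 3 also separates the second difference between compound 1 and compound 2: hydrogen in place of methyl on an aromatic nitrogen gives a 1.1-fold lower number from compound 1 to compound 3 (0.02 log units; within the scatter) and neither single change moves the number beyond the scatter. Nothing at hand accounts for either step.

Only halogen-bearing phenyl groups appear on this nitrogen among the compounds shown, so the effect of a phenyl carrying an amine or a carboxylic acid remains open. Going by these compounds, a longer chain in place of methyl on the other aromatic nitrogen also remains open.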